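Ring contraction on the amine-bearing side chain

This account rests on a few compounds, and the source may have more. Where it says the series, first, only, none or still open, it means among the compounds named here.

compound 1 `Oc1ccc(CNc2cc(C(F)(F)F)cc3[nH]ncc23)cc1`: 36700 nM
compound 2 `FC(F)(F)c1cc(NC[C@H]2CCCN2)c2cn[nH]c2c1`: 9580 nM

In an assay for inhibition of Indoleamine 2,3-dioxygenase 1 (Homo sapiens), with stated times of 10 min and 60 min (on this read-out lower numbers stand for stronger inhibition and higher numbers for weaker inhibition), compound 2 gives 9580 nM, the lowest of the two numbers. Compound 1 gives 36700 nM, and the step of a 3.8-fold lower number from compound 1 to compound 2 (0.58 log units; beyond the scatter) lies beyond the scatter. Compound 3 `FC(F)(F)c1cc(NCC2CNC2)c2cn[nH]c2c1` differs from compound 2 by azetidin-3-yl in place of pyrrolidin-2-yl on a saturated chain carbon bound to a nitrogen on an aromatic ring. Among the compounds with values here, no measured step exchanges one saturated amine ring for another; the only step, 4-hydroxyphenyl to pyrrolidin-2-yl, was modest. A smaller shift, if any, is expected here. Compound 3 is therefore estimated at 12000 nM (range 4000 nM to 40000 nM). The expected step of a 1.3-fold higher number from compound 2 to compound 3 (0.10 log units; within the scatter) would sit within the scatter.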

Compound 3, half-maximal inhibitory concentration: > 100000 nM
Compound 3: a limit, no number; the forecaster's own chance of this, stated with the estimate: 10%; middle value at least 8.3-fold (0.92 log units) from the limit.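

Compound 3 reads only as a limit of the assay, not as a number: the limit of > 100000 nM in this assay, at which 1 of the 3 values shown sits. Azetidin-3-yl in place of pyrrolidin-2-yl gives an at least 10-fold higher number from compound 2 to compound 3 (1.01 log units; beyond the scatter), so at this place a single change of saturated amine ring can matter far more than the earlier step suggested. Azetidin-3-yl also falls behind 4-hydroxyphenyl, with an at least 2.7-fold higher number from compound 1 to compound 3 (0.43 log units; beyond the scatter), so a saturated amine ring alone does not secure the gain seen in compound 2.

Azetidin-2-yl or piperidin-2-yl on the same chain would help separate ring size from the ring's attachment point. Going by these compounds, the role of the defined stereocentre in compound 2 also remains open.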